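The source may report more compounds than this note shows. Statements on the series, on what has been measured and on what is new or still open speak of the compounds shown alone.

In a functional assay on DU-145 cells (Homo sapiens) for cytotoxicity, read by MTT assay, with a stated time of 72 h (a lower number here means a stronger inhibitor, a higher number a weaker inhibitor), the three measured compounds stand as follows:

Compound 1 `C#CCn1cc(C(=O)NC(CC(=O)Nc2ccccn2)c2ccccc2)c(=O)c2ccc(Cl)nc21`: 4900 nM
Compound 2 `C#CCn1cc(C(=O)NC(CC(=O)NC2CCCCC2)c2ccccc2)c(=O)c2cc(F)c(Cl)nc21`: 8030 nM
Compound 3 `C#CCn1cc(C(=O)NC(CC(=O)Nc2ccccc2)c2ccccc2)c(=O)c2cccnc21`: 7200 nM

Compound 1 stands at the low end of these three numbers, but both compound 3 and compound 2 lie within the scatter of it, so nothing separates them with confidence. Compound 4 `C#CCn1cc(C(=O)NC(CC(=O)NC2CCCC2)c2ccccc2)c(=O)c2ccc(Cl)nc21` differs from compound 1 in one place: cyclopentyl in place of pyridin-2-yl on an amide-type nitrogen. Going by the values given here, no pair of measured compounds shows this change alone, and compound 2, which also carries a saturated ring on the amide nitrogen, differs from compound 1 in a second place as well, so its number can only be noted. Compound 4 is therefore expected near compound 1, at 6500 nM, in a range of 3000 nM to 14000 nM. The step expected here, a 1.3-fold higher number from compound 1 to compound 4 (0.12 log units; within the scatter), is estimated to stay within the scatter, with no clear direction.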

Compound 4, half-maximal inhibitory concentration: > 10000 nM
Compound 4 ended at the assay's limit; the forecaster's own chance of this, stated with the estimate: 5%; middle value at least 1.5-fold (0.18 log units) away from the limit.
By their numbers in this assay, from the lowest: compounds 1, 3 and 2 (each within the scatter of the next). At a limit, above all of these: compound 4.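

In this assay compound 4 gives > 10000 nM, which is a limit of the assay and not a number. On the amide-type nitrogen, cyclopentyl in place of pyridin-2-yl gives an at least 2.0-fold higher number from compound 1 to compound 4 (0.30 log units; that floor lies within the scatter), so this first pair changing only this place fixes a floor for the step and not its size. The pair gives no sign that a non-aromatic ring of carbon only lowers the number here.

On these data alone, how far compound 4 lies past the limit stays open. So does whether a piperidin-4-yl ring or a longer alkyl chain on this nitrogen would read like cyclopentyl or like pyridin-2-yl.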